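Series notes on the amide nitrogen of compound 1

The source may hold more compounds than are shown below. What is called first, only, known or untested is meant among the compounds shown, and "the series" means these compounds.

Among the measured compounds shown here, compound 1 `Cc1ccccc1C#Cc1ccc2c(n1)CCN(C)C2=O` stands at 776 nM in a functional assay on HEK293 cells for negative allosteric modulation of metabotropic glutamate receptor 5 (Homo sapiens), read by FLIPR and calcium flux (a higher number here means a weaker inhibitor, a lower number a stronger inhibitor), the higher of the two numbers measured so far. Its nearest neighbour is compound 2 `Cc1cccc(C#Cc2ccc3c(n2)CCN(C)C3=O)c1`, which in this assay gives 2.9 nM; the step between them, a 270-fold lower number from compound 1 to compound 2 (2.43 log units; beyond the scatter), comes from the 3-methylphenyl in place of 2-methylphenyl on the triple-bonded carbon. Compound 3 `CN1CCc2nc(C#Cc3cccnc3)ccc2C1=O` is reported in this assay as "not active" (no number reported), without a number.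

Compound 4 `Cc1ccccc1C#Cc1ccc2c(n1)CCN(C(C)C)C2=O` keeps the 2-methylphenyl of compound 1 and differs from it only at the amide-type nitrogen in a ring: isopropyl in place of methyl on an amide-type nitrogen in a ring. For the measured compounds named here, no measured step touches this nitrogen; the single quantified step, a 270-fold lower number from compound 1 to compound 2 (2.43 log units; beyond the scatter), concerns the aryl group alone and so does not bear on the change from compound 1 to compound 4. Going by the values given here, with no precedent at this position, a step within the scatter is the expectation, and the step from compound 1 to compound 4 is estimated as a 1.2-fold higher number from compound 1 to compound 4 (0.06 log units; within the scatter). For compound 4 the estimated value in this assay is 900 nM, with a range from 250 nM to 4000 nM that is kept wide for want of any comparable change.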

Compound 4, half-maximal inhibitory concentration: 810 nM
Estimate against measurement, compound 4: 1.1-fold (0.05 log units) above; the range from low to high includes it.
By their numbers in this assay, from the lowest: compound 2; then compounds 1 and 4 (each within the scatter of the next).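

Isopropyl in place of methyl on the amide-type nitrogen in a ring gives a 1.0-fold higher number from compound 1 to compound 4 (0.02 log units; within the scatter) in this assay, the first measured step at this position in the series. Where the earlier quantified step concerned only the aryl group and was beyond the scatter, this one shows that, with the 2-methylphenyl kept, 3 heavy atoms can stand on this nitrogen in place of 1 with no difference that can be read from the scatter. No supporting data bear on why this change leaves the number within the scatter.

On these data alone, the pair speaks only for the 2-methylphenyl compounds, so whether isopropyl on this nitrogen would also leave the number within the scatter alongside the 3-methylphenyl of compound 2 stays open. Also open, as far as these compounds go, is how far this holds for other groups at the same nitrogen, such as a longer chain, a chain ending in an amine or a carboxylic acid, or a plain hydrogen in place of methyl.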